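From 4-methoxybenzyl to 3-fluorobenzyl at low growth inhibition

This account rests on a few compounds, and the source may have more. Where it says the series, first, only, none or still open, it means among the compounds named here.

In a functional assay on HL-60 cells (Homo sapiens) for inhibition, read by CCK-8 assay, with a stated time of 48 h, tested at 20 uM (on this read-out higher numbers stand for more inhibition of growth at the one concentration tested and lower numbers for less inhibition of growth), compound 1 `COc1ccc(Cc2nnc(NC(=O)/C(C#N)=C/c3ccccc3OS(=O)(=O)c3ccc(OC)cc3)s2)cc1` gives 100% and leads the three measured compounds. Compound 3 `COc1ccc(Cc2nnc(NC(=O)/C(C#N)=C/c3ccccc3OS(=O)(=O)c3ccc(Cl)cc3)s2)cc1` gives 20% and sits within the scatter of compound 2 `COc1ccc(Cc2nnc(NC(=O)/C(C#N)=C/c3ccccc3OS(=O)(=O)c3ccccc3[N+](=O)[O-])s2)cc1` at 25% while both lie far under compound 1.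

Compound 4 `N#C/C(=C\c1ccccc1OS(=O)(=O)c1ccccc1[N+](=O)[O-])C(=O)Nc1nnc(Cc2cccc(F)c2)s1` keeps the 2-nitrophenyl on the sulfonyl sulfur and differs from compound 2 by 3-fluorophenyl in place of 4-methoxyphenyl on a saturated chain carbon bound to an aromatic carbon with 3-fluorophenyl in place of 4-methoxyphenyl on a saturated chain carbon bound to an aromatic carbon. The same difference can be read as 4-methoxybenzyl to 3-fluorobenzyl.

Every measured step changes the group on a sulfonyl sulfur and none touches this place. Both a number 75 percentage points lower from compound 1 to compound 2 (beyond the scatter) and a number 80 percentage points lower from compound 1 to compound 3 (beyond the scatter) are large, while a number 5 percentage points lower from compound 2 to compound 3 (within the scatter) stays within the scatter. For the measured compounds named here, these steps show only that a single change can move this number far, so the range must stay wide, but they give no direction for the new group. No step beyond the scatter is therefore expected in this assay for this change. The estimated step is a number 5 percentage points higher from compound 2 to compound 4 (within the scatter) which stays within the scatter. For compound 4 the estimate is 30% with an expected range of 10% to 65% in this measurement.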

Compound 4, percent growth inhibition at one concentration: 23%
For compound 4 the middle estimate is 7 percentage points above the measured one; the range from low to high includes it.
By their numbers in this assay, from the lowest: compounds 3, 4 and 2 (each within the scatter of the next); then compound 1.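

The exchange of 4-methoxybenzyl for 3-fluorobenzyl is the first change shown at this place, on a saturated chain carbon bound to an aromatic carbon, and in this assay it gives a number 2 percentage points lower from compound 2 to compound 4 (within the scatter) with the 2-nitrophenyl on the sulfonyl sulfur kept. For this one pair, the change of group on the saturated chain carbon therefore does not move the growth inhibition beyond the scatter, unlike the large steps seen when the group on the sulfonyl sulfur changes from that of compound 1. No measurement at hand offers an explanation for this result.

Because compound 2 and compound 4 both sit at a low number, the pair cannot tell whether 3-fluorobenzyl would also leave the number unchanged on the background of compound 1, which gives 100% and carries a 4-methoxyphenyl on the sulfonyl sulfur. It also leaves open how this place would respond to groups of a different kind, such as a 4-aminobenzyl, a 4-carboxybenzyl or a longer phenethyl chain.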